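Dithiocarbamate butenolides: removing the aryl methyl

The compounds below may be only part of what the source reports. "The series", "measured", "known", "first", "only" and "open" are said of these compounds alone.

Values in a functional assay on EC9706 cells (Homo sapiens) for antiproliferative activity, read by MTT assay, with a stated time of 72 h (a higher number here means a weaker inhibitor, a lower number a stronger inhibitor), so far:
compound 1 `CN1CCN(C(=S)SCC2=CCOC2=O)CC1`: 14300 nM
compound 2 `CCNC(=S)SCC1=CCOC1=O`: 44400 nM
compound 3 `Cc1ccc(NC(=S)SCC2=CCOC2=O)cc1`: 91000 nM

Compound 3 holds the highest number of the three in this assay; compound 2 stands one step below it, beyond the scatter, and compound 1 lies furthest below. The untested compound 4 `O=C1OCC=C1CSC(=S)Nc1ccccc1` differs from compound 3 in a single place: hydrogen in place of methyl on an aromatic carbon. No measured pair in this set isolates such a change, so the step has no precedent among the numbers shown. Loss of one carbon from the six-membered aromatic ring of carbon only is expected to shift the number little, so the expected step of a 1.2-fold lower number from compound 3 to compound 4 (0.08 log units; within the scatter) stays near the scatter. Compound 4 is expected to give about 75000 nM in this assay, within 30000 nM to 180000 nM.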

Compound 4, half-maximal inhibitory concentration: 16200 nM
Estimate against measurement, compound 4: 4.6-fold (0.67 log units) above; measured number outside the range, below it.
By their numbers in this assay, from the lowest: compounds 1 and 4 (each within the scatter of the next); then compound 2; then compound 3.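

In this assay, within the data shown here, the first pair differing in one place gives a 5.6-fold lower number from compound 3 to compound 4 (0.75 log units; beyond the scatter), a step beyond the scatter. This aromatic position is therefore not indifferent: a single methyl on the carbon para to a large group separates compound 3, the weaker inhibitor, from compound 4. Nothing measured here accounts for the step.

Still open, going by these compounds, is how a chlorine, a methoxy group or an ethyl group on the same carbon would compare with compound 4. On these data alone, it is equally open whether the methyl-to-hydrogen step carries over to other positions on the ring.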